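The compounds below may be only part of what the source reports. "The series", "measured", "known", "first", "only" and "open" are said of these compounds alone.

Measured so far in a functional assay on MDA-MB-231 cells (Homo sapiens) for inhibition, read by MTT assay, with a stated time of 72 h; on this read-out lower numbers stand for stronger inhibition and higher numbers for weaker inhibition:
- compound 1 `CCN(CC)CCCn1c(=O)c(=Cc2ccc(F)cc2F)s/c1=C1\C(=O)Nc2ccc(Cl)cc21`: > 200000 nM
- compound 2 `CN(C)CCn1c(=O)c(=Cc2ccc(F)cc2F)s/c1=C1\C(=O)Nc2cc(F)ccc21`: 8440 nM
- compound 3 `CCN(CC)CCCn1c(=O)c(=Cc2ccc(O)cc2)s/c1=C1\C(=O)Nc2ccc(C)cc21`: 1810 nM

The value of compound 1 is a limit of this assay, not a number: compound 1 sits at the limit of > 200000 nM in this assay, at which 1 of the 3 values shown sits. Compounds 2 and 3 each gave a number, so compound 1 is the only one of the three with no measured value.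

Compound 4 `CCN(CC)CCCn1c(=O)c(=Cc2ccc(F)cc2F)s/c1=C1\C(=O)Nc2ccccc21` has not yet been measured. It differs from compound 1 in one place: hydrogen in place of chloro on an aromatic carbon.

Going by the values given here, no measured step tells how this change acts in this assay. Since compound 1 gave only a limit, any number for compound 4 would mean a move toward stronger inhibition, and the size of that move is open. Compound 4 is expected at 50000 nM, within 5000 nM to 200000 nM, an estimated step of an at least 4.0-fold lower number from compound 1 to compound 4 (0.60 log units; beyond the scatter).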

Compound 4, half-maximal inhibitory concentration: > 200000 nM
Compound 4 ended at the assay's limit (the forecaster's own chance of this, stated with the estimate: 40%); middle value at least 4.0-fold (0.60 log units) away from the limit.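

Compound 1 and compound 4 both stop at a limit of this assay and neither gives a number, so no step can be read between them: the limit of > 200000 nM in this assay, at which 2 of the 4 values shown sit. On these data alone, whether hydrogen in place of chloro changes inhibition at all stays open.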